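A few compounds are considered here, and "the series" means these few. Any claim that something is new, unique, unknown or untested is made for them only; others in the source may bear on it.

The measured compounds:
compound 1 `O=C1COc2ccc(-c3[nH]c(-c4ccc(C(F)(F)F)cc4)nc3-c3ccccc3)cc2N1`, which in a functional assay on A549 cells (Homo sapiens) for cytotoxicity, read by colorimetric assay and MTT assay, with a stated time of 3 days, tested at 1 uM (on this read-out lower numbers stand for a stronger effect and higher numbers for a weaker effect at the one concentration tested), gives 103%
compound 2 `O=C1COc2ccc(-c3nn(-c4ccc(F)cc4)cc3-c3ccccc3)cc2N1`, which in this assay gives 78.2%
compound 3 `O=C1COc2ccc(-c3[nH]c(-c4c[nH]c5ncccc45)nc3-c3ccccc3)cc2N1`, which in this assay gives 100%

Among these three, compound 2 stands lowest in this assay: compound 3 lies above it by a gap beyond the scatter, and compound 1 lies further above it, also beyond the scatter. Compound 2 is thus the one with the strongest effect of the three on this read-out. Among the measured compounds shown here, the only step between two measured compounds that differ in one place is a number 3 percentage points lower from compound 1 to compound 3 (within the scatter), and it concerns an exchange of aromatic groups on the core of compound 1, not the fluoro of compound 2.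

Compound 4 `O=C1COc2ccc(-c3nn(-c4ccccc4)cc3-c3ccccc3)cc2N1` differs from compound 2 by hydrogen in place of fluoro on an aromatic carbon. For the measured compounds named here, no measured step touches this kind of change, so the data give no direction for it. One therefore expects compound 4 to stay close to compound 2, with a step of a number 1.8 percentage points higher from compound 2 to compound 4 (within the scatter) that is not beyond the scatter. On that basis compound 4 is estimated at 80% in this assay, within a range from 62% to 98%.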

Compound 4, a percentage reported as activity, at one concentration (the size of the read-out at that concentration, not a potency): 92.2%
Beside the measured number, compound 4's estimate is 12.2 percentage points below it; low and high end bracket the measured number.
By their numbers in this assay, from the lowest: compound 2; then compounds 4, 3 and 1 (each within the scatter of the next, the first and the last beyond it).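

Among the compounds shown here, the step of a number 14 percentage points higher from compound 2 to compound 4 (beyond the scatter) is the first measured change at this place, and in this assay it shows that the exchange of 4-fluorophenyl to phenyl, on an aromatic carbon para to a large group, moves the number towards a weaker effect at the one concentration tested. For the compounds shown here, the single fluoro therefore matters on this read-out, whereas the only earlier step, a number 3 percentage points lower from compound 1 to compound 3 (within the scatter) and thus within the scatter, exchanged two much larger aromatic groups on the core of compound 1. Nothing measured here explains why the loss of this one atom changes the number, and the data offer no evidence for a cause.

Whether the effect is particular to fluoro stays open, since the compounds shown do not tell how chloro, methoxy, an amine or a nitrile would read at this same place compared with compound 2. Also open, going by these compounds, is whether the fluoro would give a step of similar size on the core of compound 1, and whether a difference seen at one concentration would hold across a range of concentrations.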